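A few compounds are considered here, and "the series" means these few. Any claim that something is new, unique, unknown or untested is made for them only; others in the source may bear on it.

Compound 2 `O=C1OC(c2ccc([N+](=O)[O-])cc2)=N/C1=C\c1ccncc1` gives 0% in an assay on isolated protein for inhibition of Death-associated protein kinase 3 (Homo sapiens), tested at 1 uM (on this read-out higher numbers stand for a stronger effect at the one concentration tested and lower numbers for a weaker effect), and stands level with compound 1 `O=C1OC(c2ccc(Cl)c([N+](=O)[O-])c2)=N/C1=C\c1ccncc1`, which gives 0% in this assay, with no change at the digits shown and together the lowest of the three numbers. Compound 3 `O=C1OC(c2cc(I)ccc2Cl)=N/C1=C\c1ccncc1` gives 83%, a number far higher and beyond the scatter. Compound 4 `O=C1OC(c2ccccc2)=N/C1=C\c1ccncc1` has not yet been measured; it differs from compound 2 by hydrogen in place of nitro on an aromatic carbon. Among the measured compounds shown here, no measured pair shows this change on its own. Compound 3 carries no nitro and gives 83%, so a step upward beyond the scatter from compound 2 is expected, estimated as a number 35 percentage points higher from compound 2 to compound 4 (beyond the scatter) in this assay. Compound 4 is therefore expected to give about 35%, in a range from 5% to 75%.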

Compound 4, a percentage reported as inhibition, at one concentration (the size of the read-out at that concentration, not a potency): 0%
For compound 4 the middle estimate is 35 percentage points above the measured one; measured number outside the range, below it.
By their numbers in this assay, from the lowest: compounds 1, 2 and 4 (each within the scatter of the next); then compound 3.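

In this assay, hydrogen in place of nitro on this aromatic carbon, para to a large group, brings no change at the digits printed from compound 2 to compound 4 (within the scatter). Taking the nitro away from this position is therefore not enough on its own to raise the read-out. No measurement here explains this result. Going by these compounds, it remains open whether another group on this carbon, such as an amine, a methoxy group or a carboxylic acid, would change the read-out. Among the compounds shown here, also open is which part of the ring substitution goes with the 83% of compound 3 , since no single-change step connects it to the others.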